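A few compounds are considered here, and "the series" means these few. Any claim that something is new, unique, unknown or untested is made for them only; others in the source may bear on it.

Measured in a functional assay on NCI-H1993 cells (Homo sapiens) for inhibition, read by CCK-8 assay, with a stated time of 72 h; on this read-out lower numbers stand for stronger inhibition and higher numbers for weaker inhibition:
- compound 1 `CC(c1cc2cccnc2cc1F)n1cnc2ncc(-c3cnn(C)c3)nc21`: 31.3 nM
- compound 2 `CCC(c1cc2cccnc2cc1F)n1cnc2ncc(-c3cnn(C)c3)nc21`: "not determined" (no result reported)
- compound 3 `Cc1cc2ncccc2cc1C(C)n1cnc2ncc(-c3cnn(C)c3)nc21`: "not determined" (no result reported)

Among the measured compounds shown here, compound 1 holds the only number here, so it cannot be ranked against compounds 2 and 3, and it serves as the sole reference point. The open question concerns compound 4 `CC(c1cc2cccnc2cc1F)n1cnc2ncc(-c3ccccc3)nc21`, which keeps the core of compound 1 but carries phenyl in place of 1-methyl-1H-pyrazol-4-yl on an aromatic carbon. For the measured compounds named here, no measured pair shows this exchange, so the expectation is a judgement rather than a trend. Weaker inhibition, by a step beyond the usual scatter, is expected. The estimated change is a 4.8-fold higher number from compound 1 to compound 4 (0.68 log units; beyond the scatter). For compound 4 the expected value is 150 nM, within an estimated range of 40 nM to 600 nM.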

Compound 4, half-maximal inhibitory concentration: 570 nM
Beside the measured number, compound 4's estimate is 3.8-fold (0.58 log units) below it; the range from low to high includes it.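

In this assay, among the compounds shown here, phenyl in place of 1-methyl-1H-pyrazol-4-yl gives an 18-fold higher number from compound 1 to compound 4 (1.26 log units; beyond the scatter) and so a clear loss of inhibition, which the earlier compounds, with only one number among them, could not show. This aromatic carbon is therefore sensitive to the group it carries, even though both groups have 6 heavy atoms and one aromatic ring. No measurement shown here accounts for the loss. From the compounds shown here alone, whether a pyridine ring or a morpholine at this carbon would restore inhibition remains open. Going by these compounds, the effect of the same exchange on other versions of the core also remains open.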